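The source may hold more compounds than are shown below. What is called first, only, known or untested is meant among the compounds shown, and "the series" means these compounds.

Of the compounds shown here, three with a shared core have been measured in a physicochemical assay for solubility; a higher number here means a more soluble compound, a lower number a less soluble compound. Compound 1 `C[C@H](Oc1ccc(S(C)(=O)=O)cc1C(=O)N1Cc2ccc(N3CCN(C)CC3)cc2C1)C(F)(F)F` gives 490 ug/mL. Compound 2 `C[C@H](Oc1ccc(S(C)(=O)=O)cc1C(=O)N1Cc2ccc(C3CCCCO3)cc2C1)C(F)(F)F` gives < 1 ug/mL, which is a limit of the assay and not a number. Compound 3 `C[C@H](Oc1ccc(S(C)(=O)=O)cc1C(=O)N1Cc2ccc(C3CCOCC3)cc2C1)C(F)(F)F` gives 76 ug/mL, the lower of the two actual numbers, and the step down to it is a 6.4-fold lower number from compound 1 to compound 3 (0.81 log units; beyond the scatter).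

Compound 4 `CS(=O)(=O)c1ccc(OCCC(F)(F)F)c(C(=O)N2Cc3ccc(C4CCOCC4)cc3C2)c1` keeps the oxan-4-yl group of compound 3 and differs elsewhere: 3,3,3-trifluoropropyl in place of 1-(trifluoromethyl)ethyl on an oxygen on an aromatic ring. Here 3,3,3-trifluoropropyl stands in place of 1-(trifluoromethyl)ethyl on an oxygen on an aromatic ring, with the same atoms joined differently. Among the compounds with values here, no measured step touches this group. The closest guide is an at least 76-fold higher number from compound 2 to compound 3 (1.88 log units; beyond the scatter), also a change of same atoms joined differently, though at the oxan group. The other change at that site, an at least 490-fold lower number from compound 1 to compound 2 (2.69 log units; beyond the scatter), was also large. Some effect is therefore expected, and the expected outcome in this assay is a modest drop, a 2.5-fold lower number from compound 3 to compound 4 (0.40 log units; beyond the scatter), held only tentatively. For compound 4 the estimated value is 30 ug/mL, with an expected range of 6 ug/mL to 130 ug/mL.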

Compound 4, solubility: 334 ug/mL
Beside the measured number, compound 4's estimate is 11-fold (1.05 log units) below it; the whole stated range lies below it.
By their numbers in this assay, from the lowest: compound 3; then compounds 4 and 1 (each within the scatter of the next). At a limit, below all of these: compound 2.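

The chain on the oxygen on the aromatic ring stayed the same through compounds 1, 2 and 3, and compound 4 shows that this site also moves the read-out: in this assay the change gives a 4.4-fold higher number from compound 3 to compound 4 (0.64 log units; beyond the scatter) with the same atoms joined differently. So rearranging atoms matters here as well as at the oxan group, and 3,3,3-trifluoropropyl achieves this without the defined stereocentre of 1-(trifluoromethyl)ethyl. Nothing measured in this set accounts for the rise.

The 3,3,3-trifluoropropyl group is shown only with oxan-4-yl, so whether the same step holds with 4-methylpiperazin-1-yl or oxan-2-yl remains open. Also open, from the compounds shown here alone, is how a longer chain such as 4,4,4-trifluorobutyl, or a plain propyl chain without fluorine, would read on that oxygen.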